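Iodo for Chloro on the Cyclopentenone Ring

This account rests on a few compounds, and the source may have more. Where it says the series, first, only, none or still open, it means among the compounds named here.

Compound 2 `CCCCC/C=C\C[C@@]1(O)C=C(Cl)C(=O)/C1=C/C=C/CCCC(=O)OC`: 2700 nM
Compound 3 `CCCCC/C=C\C[C@]1(O)C=CC(=O)/C1=C\C=C\CCCC(=O)OC`: 7900 nM
Compound 1 `CCCCC/C=C\C[C@@]1(O)C=C(Cl)C(=O)/C1=C\C=C\CCCC(=O)OC`: "not determined" (no result reported)

Three compounds share the core of compound 2, and two of them have numbers in a functional assay on HT-29 cells (Homo sapiens) for cytotoxicity, read by sulforhodamine B assay, with a stated time of 72 h; a lower number here means a stronger inhibitor, a higher number a weaker inhibitor. Compound 2 gives 2700 nM in this assay. Where compound 2 carries chloro, compound 3 carries a hydrogen. Compound 3 gives 7900 nM in this assay, a higher number than compound 2 by a gap beyond the scatter. Compound 1 gives "not determined" (no result reported) in this assay; (the fact that compounds 1 and 2 differ only in the configuration as drawn), so nothing on the configuration can be said from numbers. For the measured compounds named here, compound 2 therefore stands at the lowest number of the two that exist, with compound 3 the only comparison.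

Compound 4 `CCCCC/C=C\C[C@@]1(O)C=C(I)C(=O)/C1=C/C=C/CCCC(=O)OC` is the next step. Its difference from compound 2 is iodo in place of chloro on a double-bonded ring carbon. Going by the values given here, since no step between two measured compounds concerns the halogen itself, the step to compound 4 is expected to lie within the scatter, with no clear direction. The expected step is a 1.1-fold lower number from compound 2 to compound 4 (0.03 log units; within the scatter). Compound 4 is estimated to give 2500 nM in this assay, within a range from 1000 nM to 6000 nM.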

Compound 4, half-maximal inhibitory concentration: 6500 nM
Compound 4: the middle estimate sits 2.6-fold (0.41 log units) below what was measured; the whole stated range lies below it.
By their numbers in this assay, from the lowest: compound 2; then compounds 4 and 3 (each within the scatter of the next).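

In this assay, for the compounds shown here, putting iodo in place of chloro on the double-bonded ring carbon gives a 2.4-fold higher number from compound 2 to compound 4 (0.38 log units; beyond the scatter), the first step that isolates the halogen at this position and shows that the two halogens are not interchangeable there. The change is a simple one, with one heavy atom leaving and one entering, no hydrogen-bond donor or acceptor on either side and no net charge, yet the step is modest but lies beyond the scatter, and it favours chloro, the halogen with the lower number of this pair. Nothing in the information at hand bears on why the number rises with iodo.

As far as these compounds go, what bromo, fluoro or a methyl group on this same ring carbon would give remains open, so these two halogens alone do not define a trend at this position. From the compounds shown here alone, it is also open whether the step would hold with a carboxylic acid in place of the methyl ester, or with a shorter chain in place of the oct-2-en-1-yl group.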